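The source may report more compounds than this note shows. Statements on the series, on what has been measured and on what is new or still open speak of the compounds shown alone.

In a functional assay on L1210 cells (Mus musculus) for inhibition (on this read-out lower numbers stand for stronger inhibition and higher numbers for weaker inhibition), two compounds sharing one core have been measured so far. Compound 1 (`CCCCNC(=O)CCC(NC(=O)c1ccc(N(C)Cc2cnc3nc(N)nc(N)c3n2)cc1)C(=O)O`) gives 0.09 uM while compound 2 (`CN(Cc1cnc2nc(N)nc(N)c2n1)c1ccc(C(=O)NC(CCC(=O)O)C(=O)OC(C)(C)C)cc1`) gives 5.2 uM and so stands as the higher of the two numbers, a gap well beyond the scatter. The two compounds differ in more than one place, so this gap cannot be tied to any single structural change.

Compound 3 (`COC(=O)CCC(NC(=O)c1ccc(N(C)Cc2cnc3nc(N)nc(N)c3n2)cc1)C(=O)OC(C)(C)C`) departs from compound 2 in one place only. The change is methyl in place of hydrogen on an oxygen next to a carbonyl group and it turns carboxy into methoxycarbonyl, with methyl in place of hydrogen on an oxygen next to a carbonyl group. For the measured compounds named here, no measured pair in this set shows what such a change does in this assay, so the expectation is weakly grounded and starts from compound 2 at 5.2 uM as its anchor. The expected result is a 1.7-fold lower number from compound 2 to compound 3 (0.24 log units; within the scatter) and this estimated step, slightly downward, stays within the scatter. Compound 3 is estimated to read 3 uM in this assay (expected range 0.6 uM to 15 uM).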

Compound 3, concentration for 50% inhibition: 9.7 uM
Estimate against measurement, compound 3: 3.2-fold (0.51 log units) below, within the range that was stated.
By their numbers in this assay, from the lowest: compound 1; then compounds 2 and 3 (each within the scatter of the next).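

Methyl in place of hydrogen on an oxygen next to a carbonyl group gives, in this assay, a 1.9-fold higher number from compound 2 to compound 3 (0.27 log units; within the scatter). For the compounds shown here, this is the first pair here that differs in one place only, and it shows that at this place carboxy and methoxycarbonyl cannot be told apart in this assay, so the free carboxy of compound 2 is not needed to keep its reading within the scatter of compound 3. No measurement offered here explains why the two compounds read alike.

The compounds shown leave open whether a longer chain on this oxygen, such as ethyl or benzyl, or an amide or an amine in place of the carboxy, would also stay within the scatter of compound 2. They also leave open whether the same change from carboxy to methoxycarbonyl would stay as small on a different parent, such as compound 1, which carries a butyl amide in another part of the molecule.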